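Shortening the chain from compound 2 to compound 3

The compounds below may be only part of what the source reports. "The series", "measured", "known", "first", "only" and "open" are said of these compounds alone.

Measured in a functional assay on the whole organism (stomach) with Rattus norvegicus as the target; on this read-out higher numbers stand for an effect only at larger amounts of compound and lower numbers for an effect already at smaller amounts:
Compound 1 `CCCCCCCCCC/N=C/N1CCC(C(c2ccccc2)c2ccccc2)CC1`, 7.8 mg/kg
Compound 2 `CCCCCCCCC/N=C/N1CCC(C(c2ccccc2)c2ccccc2)CC1`, 10.8 mg/kg

The values of compound 1 and compound 2 lie within the scatter of each other, so compound 2 cannot be placed apart from compound 1. Compound 3 `CCCCCCC/N=C/N1CCC(C(c2ccccc2)c2ccccc2)CC1` has not yet been measured. It differs from compound 2 by hydrogen in place of ethyl on a saturated chain carbon, seven bonds along the chain from a double-bonded nitrogen, on a saturated chain carbon, seven bonds along the chain from a double-bonded nitrogen. Among the measured compounds shown here, one measured step bears on this change, hydrogen in place of methyl on the same chain: a 1.4-fold higher number from compound 1 to compound 2 (0.14 log units; within the scatter). That step is small and stands alone, so it gives only weak guidance. A modest move toward a higher number in this assay is expected, possibly still close to the scatter. The expected change is a 1.4-fold higher number from compound 2 to compound 3 (0.14 log units; within the scatter). Compound 3 is estimated at 15 mg/kg, with an expected range from 7 mg/kg to 32 mg/kg.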

Compound 3, dose for half-maximal effect: 11.5 mg/kg
Estimate against measurement, compound 3: 1.3-fold (0.12 log units) above; low and high end bracket the measured number.
By their numbers in this assay, from the lowest: compounds 1, 2 and 3 (each within the scatter of the next).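

In this assay, hydrogen in place of ethyl, seven bonds along the chain from a double-bonded nitrogen, gives a 1.1-fold higher number from compound 2 to compound 3 (0.03 log units; within the scatter) and so leaves no readable difference after a larger removal than the earlier step. Hydrogen in place of propyl at that same place gives a 1.5-fold higher number from compound 1 to compound 3 (0.17 log units; within the scatter) and likewise stays inside the scatter, so compound 1, compound 2 and compound 3 cannot be told apart by chain length in this assay. Nothing measured here offers an explanation for this lack of separation.

As far as these compounds go, whether the same holds for a much shorter chain or a longer chain remains open. From the compounds shown here alone, it is also open whether an amine or a carboxylic acid in place of the ethyl would move the number beyond the scatter.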